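This account rests on a few compounds, and the source may have more. Where it says the series, first, only, none or still open, it means among the compounds named here.

Measured so far:
- compound 1 `C=CCNC(=O)[C@@H](NC(=O)[C@@](O)(CCCN(Cc1ccc(Br)cc1)NC(=O)[C@@H](NC(=O)OC)C(C)(C)C)Cc1ccc(C=C)cc1)C(C)(C)C` gives 44000 nM
- compound 2 `C=CCNC(=O)[C@@H](NC(=O)[C@@](O)(CCCN(Cc1ccc(Br)cc1)NC(=O)[C@@H](NC(=O)OC)C(C)(C)C)Cc1ccc(Br)cc1)C(C)(C)C` gives 29000 nM

Not yet measured:
- compound 3 `C=CCNC(=O)[C@@H](NC(=O)[C@](O)(CCCN(Cc1ccc(Br)cc1)NC(=O)[C@@H](NC(=O)OC)C(C)(C)C)Cc1ccc(C=C)cc1)C(C)(C)C`

In an ADME assay on MT4 cells (Homo sapiens) for cytotoxicity, read by XTT assay, with a stated time of 5 days (on this read-out lower numbers stand for higher toxicity in this test and higher numbers for lower toxicity in this test), compound 1 gives 44000 nM and compound 2 gives 29000 nM, two numbers within the scatter of each other, so compound 1 holds no separate place in this short series.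

Compound 3 is related to compound 1 as follows: the two compounds have the same atoms and bonds and differ only in configuration as drawn: 1 of 3 stereo elements differ; a stereocentre at a saturated chain carbon is drawn R in compound 1 and S in compound 3. Among the measured compounds shown here, only one measured step is available, a 1.5-fold lower number from compound 1 to compound 2 (0.18 log units; within the scatter), which lies within the scatter. That step is a bromo in place of vinyl on an aromatic carbon, so it leaves the configuration untouched and bears on the present change only indirectly. For the measured compounds named here, no measured pair differs in configuration alone, so the data give no size for such a change. With no evidence for a larger shift, no step beyond the scatter is expected, and no direction is favoured in this assay. The expected step is a 1.1-fold lower number from compound 1 to compound 3 (0.04 log units; within the scatter), and this remains an estimate. For compound 3 the estimated value is 40000 nM, with an expected range from 20000 nM to 80000 nM as the likely span.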

Compound 3, half-maximal cytotoxic concentration: 25000 nM
Estimate against measurement, compound 3: 1.6-fold (0.20 log units) above; the range from low to high includes it.
By their numbers in this assay, from the lowest: compounds 3, 2 and 1 (each within the scatter of the next).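

In this assay, the stereocentre at the saturated chain carbon now has a measured step of its own, where the earlier pair spoke only to the aromatic substituent: a 1.8-fold lower number from compound 1 to compound 3 (0.25 log units; within the scatter). Drawing this centre S rather than R therefore gives no separation from the R form in this test, and on these two compounds the configuration at this carbon does not set the cytotoxicity read-out apart beyond ordinary repeat variation. The pair is a clean test of this one centre, with no second structural change to weigh against the step: the fact that compounds 1 and 3 differ only in the configuration as drawn

Going by these compounds, whether the same holds with bromo in place of vinyl on the aromatic carbon remains open, as one pair at one centre says nothing about the other two stereo elements or about other substituents. Also open, on these data alone, is how this centre behaves when a nitrile, an amine or a carboxylic acid sits on that aromatic carbon, and whether any such group would give a step beyond the scatter.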